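Trading Hydroxyethoxy for Aminopropyl: Expected Effect on Aromatase

This account rests on a few compounds, and the source may have more. Where it says the series, first, only, none or still open, it means among the compounds named here.

Compound 2 `CC/C(=C(/c1ccc(O)cc1)c1ccc(OCCO)cc1)c1ccccc1` gives 30500 nM in an assay on isolated protein for inhibition of Aromatase (Homo sapiens), read by fluorescence, with a stated time of 30 min (on this read-out lower numbers stand for stronger inhibition and higher numbers for weaker inhibition), the highest of the three numbers measured. Compound 3 `CCC/C(=C(/c1ccc(O)cc1)c1ccc(OCCN)cc1)c1ccccc1` gives 261 nM, and compound 1 `NCCOc1ccc(/C(=C(\CCCl)c2ccccc2)c2ccc(O)cc2)cc1` gives 143 nM; both lie far lower than compound 2, beyond the scatter. Compound 4 `CC/C(=C(/c1ccc(O)cc1)c1ccc(CCCN)cc1)c1ccccc1` differs from compound 2 by 3-aminopropyl in place of 2-hydroxyethoxy on an aromatic carbon. Among the compounds with values here, no measured step isolates this change: the only single-point step, a 1.8-fold higher number from compound 1 to compound 3 (0.26 log units; within the scatter), concerns the chain and stays within the scatter. Compounds 2 and 3 differ in two places at once, yet their values show the amine-bearing compound sitting much lower. Compound 4 also carries an amine, so a large fall is expected for compound 4, a 38-fold lower number from compound 2 to compound 4 (1.58 log units; beyond the scatter). Compound 4 is estimated at 800 nM, within 150 nM to 5000 nM.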

Compound 4, half-maximal inhibitory concentration: 7340 nM
Beside the measured number, compound 4's estimate is 9.2-fold (0.96 log units) below it; measured number outside the range, above it.
By their numbers in this assay, from the lowest: compounds 1 and 3 (each within the scatter of the next); then compound 4; then compound 2.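

In this assay, within the data shown here, the exchange of 2-hydroxyethoxy for 3-aminopropyl on this aromatic carbon gives a 4.2-fold lower number from compound 2 to compound 4 (0.62 log units; beyond the scatter), the first reading of a change at this position alone. The two groups hold the same number of heavy atoms, yet nothing available accounts for the step. Still open, on these data alone, is how a 3-hydroxypropyl group or a longer amine chain would read at this position, and so whether the step belongs to the amine or to the loss of the ether oxygen.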